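The source may hold more compounds than are shown below. What is called first, only, known or untested is meant among the compounds shown, and "the series" means these compounds.

Of the compounds shown here, two of one shared core have been measured in a functional assay on UACC-257 cells (Homo sapiens) for inhibition, read by sulforhodamine B assay, with a stated time of 48 h; a lower number here means a stronger inhibitor of growth, a higher number a weaker inhibitor of growth. Compound 1 `O=C(Nc1cccc(-n2cc(-c3ccncc3)c(-c3ccc(Cl)c(O)c3)n2)c1)Nc1cccc(C(F)(F)F)c1` gives 4340 nM. Compound 2 `COc1cc(-c2nn(-c3cccc(NC(=O)Nc4ccc(Cl)c(Cl)c4)c3)cc2-c2ccncc2)ccc1Cl` gives 1040 nM, the lowest of the two numbers; compound 1 is the nearest, and the gap between them lies beyond the scatter. Compound 3 `O=C(Nc1cccc(-n2cc(-c3ccncc3)c(-c3ccc(Cl)c(O)c3)n2)c1)Nc1ccc(Cl)c(Cl)c1` is not yet measured. It differs from compound 2 by hydrogen in place of methyl on an oxygen on an aromatic ring, a hydrogen in place of methyl on an oxygen on an aromatic ring. Among the compounds with values here, no single-change step is known here, so the expected step of a 1.4-fold higher number from compound 2 to compound 3 (0.16 log units; within the scatter) is a small one, hardly beyond the scatter. Compound 3 is therefore estimated at 1500 nM, with a range from 500 nM to 5000 nM.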

Compound 3, concentration for 50% growth inhibition: 930 nM
The estimate for compound 3 lay 1.6-fold (0.21 log units) above the measured number; the range from low to high includes it.
By their numbers in this assay, from the lowest: compounds 3 and 2 (each within the scatter of the next); then compound 1.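

In this assay, methoxy and hydroxy on the aromatic ring cannot be told apart: a 1.1-fold lower number from compound 2 to compound 3 (0.05 log units; within the scatter). The group on the amide-type nitrogen matters more in this small set, since 3,4-dichlorophenyl in place of 3-(trifluoromethyl)phenyl gives a 4.7-fold lower number from compound 1 to compound 3 (0.67 log units; beyond the scatter). No independent measurement is available to explain either step.

As far as these compounds go, it remains open whether an ethoxy group or an amine on that ring would also stay within the scatter. It is also unknown how a phenyl carrying a single chlorine would compare on the amide-type nitrogen.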